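From a Substituted Phenyl Group to a Pyrrole

The source may hold more compounds than are shown below. What is called first, only, known or untested is meant among the compounds shown, and "the series" means these compounds.

Measured in a functional assay on DU-145 cells (Homo sapiens) for inhibition, read by trypan blue exclusion, with a stated time of 96 h; on this read-out higher numbers stand for weaker inhibition of growth and lower numbers for stronger inhibition of growth:
Compound 1 `Cc1ccc(S/C(=C/c2sccc2C)C(=O)c2ccc(Cl)cc2)cc1`: 50000 nM
Compound 2 `Cc1ccc(S/C(=C/c2c(O)cc(O)cc2O)C(=O)c2ccc(Cl)cc2)cc1`: > 100000 nM, a limit and not a number
Compound 3 `COc1ccc(/C=C(/Sc2ccc(C)cc2)C(=O)c2ccc(Cl)cc2)cc1O`: 1000 nM

Compound 3 stands lowest of the values shown, so it inhibits growth most strongly here. Compound 4 `Cc1ccc(S/C(=C/c2ccc[nH]2)C(=O)c2ccc(Cl)cc2)cc1` differs from it by one change: 1H-pyrrol-2-yl in place of 3-hydroxy-4-methoxyphenyl on a double-bonded chain carbon bound to a double-bonded chain carbon. For the measured compounds named here, no measured step involves 1H-pyrrol-2-yl, so the guidance is indirect. Two steps end in the 3-hydroxy-4-methoxyphenyl group of compound 3: a 50-fold lower number from compound 1 to compound 3 (1.70 log units; beyond the scatter) and an at least 100-fold lower number from compound 2 to compound 3 (2.00 log units; beyond the scatter). Both are large, and both show the other group giving the higher number. Removing that group is therefore expected to cause a large rise, a 20-fold higher number from compound 3 to compound 4 (1.30 log units; beyond the scatter). For compound 4 the estimated value is 20000 nM, with an expected range of 4000 nM to 100000 nM.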

Compound 4, concentration for 50% growth inhibition: 10000 nM
Compound 4: middle estimate off by 2.0-fold (0.30 log units), on the high side; measured number inside the range.
By their numbers in this assay, from the lowest: compound 3; then compound 4; then compound 1. At a limit, above all of these: compound 2.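

In this assay, one five-membered ring can outdo another at this place on the double-bonded chain carbon, with a 5.0-fold lower number from compound 1 to compound 4 (0.70 log units; beyond the scatter). The 1H-pyrrol-2-yl group also improves on 2,4,6-trihydroxyphenyl, with an at least 10-fold lower number from compound 2 to compound 4 (1.00 log units; beyond the scatter), yet falls short of 3-hydroxy-4-methoxyphenyl, with a 10-fold higher number from compound 3 to compound 4 (1.00 log units; beyond the scatter). Compound 2 stands at a limit and not at a number: the limit of > 100000 nM in this assay, at which 1 of the 4 values shown sits.

The compounds shown leave open whether the ring hydrogen on nitrogen matters, which a 1-methylpyrrol-2-yl group would test. They also leave open how a pyridine ring would compare at this place.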